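The source may report more compounds than this note shows. Statements on the series, on what has been measured and on what is new or still open speak of the compounds shown alone.

Compound 1 `Cc1cccc(C2(CNC(=O)Nc3c(C(C)C)cccc3C(C)C)CCCC2)c1` gives 15 nM in an assay on microsomes for inhibition of acyl-CoA:cholesterol acyltransferase (Oryctolagus cuniculus); a lower number here means a stronger inhibitor, a higher number a weaker inhibitor.
Compound 2 `Cc1ccc(C2(CNC(=O)Nc3c(C(C)C)cccc3C(C)C)CCCC2)cc1` gives 25 nM in this assay.
Compound 3 `CC(C)c1ccc(C2(CNC(=O)Nc3c(C(C)C)cccc3C(C)C)CCCC2)cc1` gives 48 nM in this assay.

Compound 3 has the highest of the three numbers. One of its two steps stays within the scatter, a 1.9-fold higher number from compound 2 to compound 3 (0.28 log units; within the scatter), the other lies beyond it, a 3.2-fold higher number from compound 1 to compound 3 (0.51 log units; beyond the scatter). Compound 4 `CC(C)c1cccc(C(C)C)c1NC(=O)NCC1(c2ccc(C(C)(C)C)cc2)CCCC1` differs from compound 3 by methyl in place of hydrogen on a saturated chain carbon bound to an aromatic carbon and two saturated chain carbons. Going by the values given here, the closest precedent is the earlier enlargement of that same group, a 1.9-fold higher number from compound 2 to compound 3 (0.28 log units; within the scatter), which did not rise above the scatter. A further methyl at that spot is therefore expected to change this assay only a little, at most a modest rise in the number. Compound 4 is expected to give 70 nM, within 30 nM to 170 nM, which means a step of a 1.5-fold higher number from compound 3 to compound 4 (0.16 log units; within the scatter).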

Compound 4, half-maximal inhibitory concentration: 63 nM
The estimate for compound 4 lay 1.1-fold (0.05 log units) above the measured number; low and high end bracket the measured number.
By their numbers in this assay, from the lowest: compounds 1, 2, 3 and 4 (each within the scatter of the next, the first and the last beyond it).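

In this assay the extra methyl that turns isopropyl into tert-butyl gives no change beyond the scatter (a 1.3-fold higher number from compound 3 to compound 4 (0.12 log units; within the scatter)). Two enlargements that each stayed within the scatter do, however, add up: replacing methyl with tert-butyl on the aromatic carbon clears it (a 2.5-fold higher number from compound 2 to compound 4 (0.40 log units; beyond the scatter)). The comparison with the 3-methylphenyl compound shows a similarly modest rise (a 4.2-fold higher number from compound 1 to compound 4 (0.62 log units; beyond the scatter)). Going by these compounds, whether a methoxy group or a carboxylic acid in place of tert-butyl would keep or lower the number remains open. Nothing measured here explains the rise in the number.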